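Aryl Carbamate Selenocyanates: Trimming a Methyl Group

The compounds below may be only part of what the source reports. "The series", "measured", "known", "first", "only" and "open" are said of these compounds alone.

Compound 1 `CC(C)COC(=O)Nc1ccc([Se]C#N)cc1`: in a functional assay on MCF7 cells (Homo sapiens) for cytotoxicity, read by MTT assay, with a stated time of 72 h (a higher number here means a weaker inhibitor of growth, a lower number a stronger inhibitor of growth), compound 1 gives 18100 nM.
Compound 2 `Cc1ccc(OC(=O)Nc2ccc([Se]C#N)cc2)cc1`: in this assay compound 2 gives 9900 nM.

Compound 2 carries the lowest of the two numbers recorded so far in this assay; its nearest neighbour is compound 1, whose number is higher, but the gap between the two lies within the usual scatter of this measurement, so no order between them can be claimed. Compound 3 `N#C[Se]c1ccc(NC(=O)Oc2ccccc2)cc1` has not yet been measured. It differs from compound 2 in one place only: hydrogen in place of methyl on an aromatic carbon. Going by the values given here, no pair of measured compounds here shows such a step, so its size is unknown from the data. Since the change removes a single carbon from the edge of the molecule, the step is expected to be small, in no clear direction, and within the scatter; the estimated step is a 1.2-fold higher number from compound 2 to compound 3 (0.08 log units; within the scatter). Compound 3 is therefore expected to give about 12000 nM in this assay, with a range from 5000 nM to 30000 nM.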

Compound 3, concentration for 50% growth inhibition: 4000 nM
Compound 3: the middle estimate sits 3.0-fold (0.48 log units) above what was measured; the measured number lies below the stated range.
By their numbers in this assay, from the lowest: compound 3; then compounds 2 and 1 (each within the scatter of the next).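

Taking the methyl group off the aromatic carbon para to a large group is not a neutral edit: in this assay the change gives a 2.5-fold lower number from compound 2 to compound 3 (0.39 log units; beyond the scatter), so this position responds to the loss of a single carbon. Phenyl in place of isobutyl on an oxygen next to a carbonyl group gives a 4.5-fold lower number from compound 1 to compound 3 (0.66 log units; beyond the scatter), a separation beyond the scatter that the earlier pair, compound 1 and compound 2, did not show. No measurement here accounts for either step.

The compounds shown hold only hydrogen and methyl at this position, so how chlorine or a methoxy group there would compare remains open. Also open, from the compounds shown here alone, is how a benzyl group or a longer chain on that oxygen would compare with phenyl and isobutyl.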